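A few compounds are considered here, and "the series" means these few. Any claim that something is new, unique, unknown or untested is made for them only; others in the source may bear on it.

Compound 1 `CN1CCC(NC(=O)c2ccc(Cn3nc(-c4cnn(C)c4)c4ccccc4c3=O)cc2)CC1` gives 47300 nM in a functional assay on HepG2 cells (Homo sapiens) for antiproliferative activity, read by MTT assay, with a stated time of 72 h; a lower number here means a stronger inhibitor, a higher number a weaker inhibitor.
Compound 2 `Cc1noc(C)c1-c1nn(Cc2ccc(C(=O)NC3CC3)cc2)c(=O)c2ccccc12` gives > 100000 nM, a limit of the assay.
Compound 3 `O=C(Nc1ccccc1Cl)c1ccc(Nc2nn(Cc3ccc(C(=O)NC4CCCCC4)cc3)c(=O)c3ccccc23)cc1` gives 82400 nM.

Compound 1 has the lowest of the two numbers in this assay; the nearest is compound 3, whose value sits within the usual scatter of it, so no order between the two can be read. The limit for compound 2 is the limit of > 100000 nM in this assay, at which 1 of the 3 values shown sits. Compound 4 `Cn1cc(-c2nn(Cc3ccc(C(=O)NC4CC(C)(C)N([O])C(C)(C)C4)cc3)c(=O)c3ccccc23)cn1` differs from compound 1 in one place: a group of 11 heavy atoms (9 carbon, 1 nitrogen, 1 oxygen; one six-membered non-aromatic ring with 1 hetero atom) in place of a group of 7 heavy atoms (6 carbon, 1 nitrogen; one six-membered non-aromatic ring with 1 hetero atom), on an amide-type nitrogen. Within the data shown here, no measured pair shows a comparable change, so the direction cannot be drawn from these data; the step that the estimate means, a 1.1-fold higher number from compound 1 to compound 4 (0.02 log units; within the scatter), is expected to stay within the scatter. Compound 4 is therefore estimated at 50000 nM in this assay, between 15000 nM and 150000 nM.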

Compound 4, half-maximal inhibitory concentration: 27400 nM
For compound 4 the middle estimate is 1.8-fold (0.26 log units) above the measured one; low and high end bracket the measured number.
By their numbers in this assay, from the lowest: compounds 4, 1 and 3 (each within the scatter of the next, the first and the last beyond it). At a limit, above all of these: compound 2.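

In this assay, among these compounds, the first measured change on this amide-type nitrogen, replacing 1-methylpiperidin-4-yl with a ring group of 11 heavy atoms, gives a 1.7-fold lower number from compound 1 to compound 4 (0.24 log units; within the scatter). The added atoms, the oxygen among them, therefore produce no change beyond the scatter, and the two compounds cannot be ordered. Nothing measured among the compounds shown bears on the reason for this step. On these data alone, it remains open whether a plain piperidin-4-yl group, or an open chain ending in an amine or a carboxylic acid, on that nitrogen would move the number beyond the scatter.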